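Swapping an anilide arm for a furan in a thiazole acid series

The compounds below may be only part of what the source reports. "The series", "measured", "known", "first", "only" and "open" are said of these compounds alone.

Measured so far:
- compound 1 `O=C(O)Cc1sc(C2COc3ccccc3O2)nc1-c1ccc(Cl)cc1`: 50%
- compound 2 `CS(=O)(=O)Nc1cccc(-c2nc(C(c3ccc(F)cc3)c3ccc(F)cc3)sc2CC(=O)O)c1`: 80%

Of the compounds shown here, two have been read in an in vitro functional assay on HEK285-7 cells for antagonist activity at prostaglandin D2 receptor 2 (Homo sapiens), read by BRET and beta-arrestin recruitment; on this read-out higher numbers stand for larger maximal responses and lower numbers for smaller maximal responses. Compound 1 gives 50% and compound 2 gives 80%, so compound 2 stands highest of the two, and its gap to compound 1 is beyond the scatter of repeated measurements. Within the data shown here, the two compounds differ in more than one place, so no single step between them can be named; their values only show that compound 2 reaches the larger maximal response.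

Compound 3 `O=C(O)Cc1sc(C(c2ccc(F)cc2)c2ccc(F)cc2)nc1-c1ccoc1` is not yet measured. It keeps the diarylmethyl group and the carboxymethyl group of compound 2 and changes one position: furan-3-yl in place of 3-(methanesulfonamido)phenyl on an aromatic carbon. Among the measured compounds shown here, with no single-point step recorded among the measured compounds, the direction of this change rests on little. The part that leaves is the larger of the two and is the one feature, apart from the diarylmethyl group, that separates compound 2 from compound 1 at the ring position. The account therefore expects a modest fall, a number 18 percentage points lower from compound 2 to compound 3 (beyond the scatter), beyond the scatter but not large. Compound 3 is estimated at 62%, within 40% to 85%.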

Compound 3, largest response reached (reported as efficacy), in percent of the reference or control that the assay uses: 80%
Beside the measured number, compound 3's estimate is 18 percentage points below it; measured number inside the range.
By their numbers in this assay, from the lowest: compound 1; then compounds 2 and 3 (each within the scatter of the next).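

In this assay, among these compounds, furan-3-yl in place of 3-(methanesulfonamido)phenyl gives no change at the digits printed from compound 2 to compound 3 (within the scatter), and this is the first step that can be read at a single position. It shows that, on this aromatic carbon next to the ring nitrogen and next to the ring atom that bears a carboxymethyl group, a group of 11 heavy atoms with a six-membered aromatic ring and 1 hydrogen-bond donor can be replaced by one of 5 heavy atoms with a five-membered aromatic ring and 0 hydrogen-bond donors, without a difference beyond the scatter in this read-out. No further measurement bears on why the two compounds read alike.

Open, going by these compounds, is whether this tolerance extends to other groups at the position, such as a plain phenyl, a furan-2-yl or a simple amine. Also open, on these data alone, is whether the same exchange would read alike if the diarylmethyl group of compound 2 and compound 3 were replaced by another group, such as a cyclohexyl.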